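Demethylation of the amine linker in compound 1

The source may hold more compounds than are shown below. What is called first, only, known or untested is meant among the compounds shown, and "the series" means these compounds.

Compound 1 `CN(Cc1ccc(Br)cc1OC(F)(F)F)CC1CCC(CNc2nc(N(C)C)c3ccccc3n2)CC1` is the tertiary-amine member of the series. In an assay on COS-1 cells for inhibition of Neuropeptide Y receptor type 5 (Homo sapiens), read by radioligand binding (on this read-out lower numbers stand for stronger inhibition and higher numbers for weaker inhibition), compound 1 gives only the limit > 1000 nM, so no number places it against its neighbours; it sits at the limit of > 1000 nM in this assay, at which 1 of the 3 values shown sits. Compound 2 `CN(C)c1nc(N[C@H]2CC[C@@H](NS(=O)(=O)c3ccc(Br)cc3OC(F)(F)F)CC2)nc2ccccc12` carries a different linker and in this assay gives 880 nM. Compound 3 `CN(C)c1nc(NCC2CCC(CNC(=O)c3ccc(Br)cc3OC(F)(F)F)CC2)nc2ccccc12`, with a further linker variant, gives 470 nM in this assay. These two values show that the shared core can reach measurable inhibition when the linker is changed.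

Compound 4 `CN(C)c1nc(NCC2CCC(CNCc3ccc(Br)cc3OC(F)(F)F)CC2)nc2ccccc12` differs from compound 1 by hydrogen in place of methyl on an amine nitrogen. Among the compounds with values here, no measured pair in the set reports such a step, so the direction rests on the limit of compound 1 alone. A modest gain is expected, but because compound 1 gives only a limit > 1000 nM the range remains wide, and the step that the limit leaves unreadable from compound 1 to compound 4 is an estimate. Compound 4 is therefore expected to give about 1500 nM in this assay, between 400 nM and 6000 nM.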

Compound 4, half-maximal inhibitory concentration: 560 nM
Beside the measured number, compound 4's estimate is 2.7-fold (0.43 log units) above it, and the stated range covers the measured number.
By their numbers in this assay, from the lowest: compounds 3, 4 and 2 (each within the scatter of the next). At a limit, above all of these: compound 1.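

In this assay compound 1 gives only a limit, > 1000 nM. With hydrogen in place of methyl on the amine nitrogen, this linker gains a measured value, as compound 4 gives 560 nM in this assay. The change gives an at least 1.7-fold lower number from compound 1 to compound 4 (0.25 log units; that floor lies within the scatter), so the data set a floor on the step and do not establish a gain beyond the scatter, and the full size of the step cannot be read because one end of it is a limit: the limit of > 1000 nM in this assay, at which 1 of the 4 values shown sits.

Only methyl and hydrogen are shown on this amine nitrogen. From the compounds shown here alone, how an ethyl group or an acetyl group at the same place would read in this assay remains open, as does whether such a group would raise or lower the number.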